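This account rests on a few compounds, and the source may have more. Where it says the series, first, only, none or still open, it means among the compounds named here.

Measured compounds:
compound 1 `Cc1ccc(C(=O)CC2CC(=O)N(c3ccc(S(N)(=O)=O)cc3)C2=O)cc1` — 980 nM
compound 2 `O=C1CCCCCC1C1CC(=O)N(c2ccccc2)C1=O` — 39500 nM

In an assay on Sf21 cells for inhibition of cytochrome c oxidase subunit 2 (Homo sapiens), read by spectrophotometry, with a stated time of 5 min (a higher number here means a weaker inhibitor, a lower number a stronger inhibitor), compound 1 gives 980 nM, the lowest of the two numbers at hand. Compound 2 differs from compound 1 in several places. In this assay, for the measured compounds named here, compound 2 gives 39500 nM, a much higher number; no single counted step links these two compounds, so their values are reported side by side and nothing further is read from the pair.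

Compound 3 `NS(=O)(=O)c1ccc(N2C(=O)CC(CC(=O)c3ccccn3)C2=O)cc1` has not yet been measured in this assay. It differs from compound 1 in one place: pyridin-2-yl in place of 4-methylphenyl on a carbonyl carbon. Going by the values given here, no measured pair in this set shows what such a change does, so the expectation rests on the value of compound 1 alone. The step from compound 1 to compound 3 is expected to be small, a 1.5-fold higher number from compound 1 to compound 3 (0.18 log units; within the scatter), and is not expected to lie beyond the scatter in either direction. Compound 3 is therefore estimated at 1500 nM in this assay, within a range of 400 nM to 6000 nM.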

Compound 3, half-maximal inhibitory concentration: 8940 nM
Estimate against measurement, compound 3: 6.0-fold (0.78 log units) below; measured number above the stated range.
By their numbers in this assay, from the lowest: compound 1; then compound 3; then compound 2.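

In this assay, the group on the carbonyl carbon turns out to matter: replacing 4-methylphenyl with pyridin-2-yl gives a 9.1-fold higher number from compound 1 to compound 3 (0.96 log units; beyond the scatter). For the compounds shown here, this is the first change in a single place in the set, and so the first direct reading of how this position responds, which the earlier contrast between compounds differing in several places could not give. Nothing at hand accounts for the size of this step.

The replacement removes a methyl group and brings in a ring nitrogen together, so the compounds shown do not separate the contribution of either one. On these data alone, it remains open whether plain phenyl, with neither feature, would fall nearer compound 1 or compound 3, and whether pyridin-4-yl, with its ring nitrogen placed differently, would give the same result as pyridin-2-yl.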